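From 3-chlorophenyl to 4-chlorophenyl: working notes on compound 3

A few compounds are considered here, and "the series" means these few. Any claim that something is new, unique, unknown or untested is made for them only; others in the source may bear on it.

In a functional assay on PC-3 cells (Homo sapiens) for antiproliferative activity, read by MTT assay, with a stated time of 48 h (a higher number here means a weaker inhibitor, a lower number a stronger inhibitor), compound 1 (`O=C(NO)c1ccc(/C=C/c2ccc(O)cc2)o1`) gives 21800 nM and compound 2 (`O=C(/C=C/c1ccc(/C=C/C(=O)c2cccc(Cl)c2)o1)NO`) gives 9600 nM as the lower of the two numbers, with a gap beyond the usual scatter. Compound 1 and compound 2 differ in more than one place, so their gap does not speak to any single change. Compound 3 (`O=C(/C=C/c1ccc(/C=C/C(=O)c2ccc(Cl)cc2)o1)NO`) carries 4-chlorophenyl in place of 3-chlorophenyl on a carbonyl carbon and is otherwise the same as compound 2. Among the measured compounds shown here, no measured pair shows this change, so in this assay no step beyond the scatter is expected, in either direction. The expected step is small, a 1.1-fold lower number from compound 2 to compound 3 (0.03 log units; within the scatter) as a working figure. For compound 3 the estimated value is 9000 nM (expected range 4000 nM to 20000 nM).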

Compound 3, half-maximal inhibitory concentration: 1350 nM
For compound 3 the middle estimate is 6.7-fold (0.82 log units) above the measured one; measured number outside the range, below it.
By their numbers in this assay, from the lowest: compound 3; then compound 2; then compound 1.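

In this assay, 4-chlorophenyl in place of 3-chlorophenyl on a carbonyl carbon gives a 7.1-fold lower number from compound 2 to compound 3 (0.85 log units; beyond the scatter), so this position is sensitive to where the chlorine stands on the phenyl ring, even though the two groups have the same heavy-atom, donor and acceptor counts. Among the compounds shown here, compound 1 and compound 2 differ in more than one place and could not show this; the present step is the only single change that can be read. No measurement offered here accounts for the size of the step.

As far as these compounds go, it remains open whether the step is specific to chlorine, which 4-bromophenyl, 4-methoxyphenyl or unsubstituted phenyl on the same carbonyl carbon would test. Also open, from the compounds shown here alone, is whether the step persists with a carboxylic acid in place of the hydroxamic acid.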